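The source may report more compounds than this note shows. Statements on the series, on what has been measured and on what is new or still open speak of the compounds shown alone.

Measured compounds in this series:
- compound 1 `Cc1ccc(-c2cc(C(=O)Nc3ccncc3Br)nn2-c2ccc3ccccc3n2)cc1`: 13100 nM
- compound 2 `Cc1ccc(-c2cc(C(=O)Nc3ccncc3)nn2-c2ccc3ccccc3n2)cc1`: 8000 nM
- compound 3 `Cc1ccc(-c2cc(C(=O)Nc3ccc(Cl)nc3Cl)nn2-c2ccc3ccccc3n2)cc1`: 14000 nM

In a functional assay on Huh-7 cells (Homo sapiens) for cytotoxicity, read by sulforhodamine B assay, with a stated time of 72 h (on this read-out lower numbers stand for stronger inhibition and higher numbers for weaker inhibition), compound 3 gives 14000 nM, the highest of the three numbers, though its gaps to compound 1 and compound 2 are both within the scatter: a 1.1-fold higher number from compound 1 to compound 3 (0.03 log units; within the scatter) and a 1.8-fold higher number from compound 2 to compound 3 (0.24 log units; within the scatter). The three measured compounds therefore cannot be ordered against one another on this read-out.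

Compound 4 `Cc1ccc(-c2cc(C(=O)NCc3cccnc3)nn2-c2ccc3ccccc3n2)cc1` differs from compound 3 only at the amide-type nitrogen: (pyridin-3-yl)methyl in place of 2,6-dichloropyridin-3-yl on an amide-type nitrogen. Within the data shown here, the steps that bear on this position are the two exchanges of the amide substituent already seen, a 1.1-fold higher number from compound 1 to compound 3 (0.03 log units; within the scatter) and a 1.8-fold higher number from compound 2 to compound 3 (0.24 log units; within the scatter), and the single-atom change a 1.6-fold lower number from compound 1 to compound 2 (0.21 log units; within the scatter); none of them moved the number beyond the scatter. Among the measured compounds shown here, no measured step introduces a methylene between the amide nitrogen and the ring, so the size of that part of the change is unknown here.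

On the measured steps, compound 4 is expected to stay close to compound 3, with a step of a 1.2-fold lower number from compound 3 to compound 4 (0.07 log units; within the scatter) that is not expected to exceed the scatter. Compound 4 is estimated at 12000 nM in this assay, with a range of 5000 nM to 30000 nM.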

Compound 4, half-maximal inhibitory concentration: 14100 nM
Estimate against measurement, compound 4: 1.2-fold (0.07 log units) below; the range from low to high includes it.
By their numbers in this assay, from the lowest: compounds 2, 1, 3 and 4 (each within the scatter of the next).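

In this assay, among these compounds, the change at the amide-type nitrogen from 2,6-dichloropyridin-3-yl to (pyridin-3-yl)methyl gives a 1.0-fold higher number from compound 3 to compound 4 (0.00 log units; within the scatter), the first step here to bring a methylene into this position. The comparisons with the other two compounds, a 1.8-fold higher number from compound 2 to compound 4 (0.25 log units; within the scatter) and a 1.1-fold higher number from compound 1 to compound 4 (0.03 log units; within the scatter), are also within the scatter, so this position has now taken a (pyridin-3-yl)methyl group as well as three directly attached pyridine rings without any step beyond the scatter. No supporting data bear on why these numbers stay within the scatter.

Still open, going by these compounds, is what the methylene contributes on its own, apart from the loss of the two chloro groups. Also open, on these data alone, is whether a group without a pyridine ring on this nitrogen, such as a cyclohexyl group or a longer chain ending in an amine or a carboxylic acid, would give a step beyond the scatter.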